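Cytotoxicity outlook for a pyridin-3-yl analogue

The compounds below may be only part of what the source reports. "The series", "measured", "known", "first", "only" and "open" are said of these compounds alone.

Compound 1 `CCOC(=O)C1=C(C)N/C(=C/c2cc(C)n(-c3ccc(N(C)C)cc3)c2C)C1=O`: 180000 nM
Compound 2 `CCOC(=O)C1=C(C)N/C(=C/c2cc(C)n(-c3ccc(SC(F)(F)F)cc3)c2C)C1=O`: 140000 nM
Compound 3 `CCOC(=O)C1=C(C)N/C(=C/c2cc(C)n(-c3ccc(S(=O)(=O)C(F)(F)F)cc3)c2C)C1=O`: 120000 nM

In an ADME assay on L6 cells (Rattus norvegicus) for cytotoxicity, read by resazurin assay, with a stated time of 72 h (on this read-out lower numbers stand for an effect already at smaller amounts and higher numbers for an effect only at larger amounts of compound), compound 1 holds the highest of the three numbers, but the gaps are small: a 1.3-fold lower number from compound 1 to compound 2 (0.11 log units; within the scatter) and a 1.5-fold lower number from compound 1 to compound 3 (0.18 log units; within the scatter). The remaining pair behaves alike, a 1.2-fold lower number from compound 2 to compound 3 (0.07 log units; within the scatter). All three steps exchange the group on the six-membered ring that sits on the ring nitrogen of the shared core, and none moves the read-out beyond the scatter.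

Compound 4 `CCOC(=O)C1=C(C)N/C(=C/c2cc(C)n(-c3cccnc3)c2C)C1=O` changes that same six-membered ring itself: pyridin-3-yl in place of 4-(dimethylamino)phenyl on an aromatic nitrogen. The measured steps bear on this change because a 1.3-fold lower number from compound 1 to compound 2 (0.11 log units; within the scatter) and a 1.5-fold lower number from compound 1 to compound 3 (0.18 log units; within the scatter) each altered this part of the molecule without a clear effect in this assay, so no step beyond the scatter is expected in this assay for compound 4 either.

Compound 4 is therefore estimated to give 150000 nM in this assay, with a range from 60000 nM to 400000 nM. The expected step is a 1.2-fold lower number from compound 1 to compound 4 (0.08 log units; within the scatter), which is estimated to stay within the scatter.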

Compound 4, half-maximal effective concentration: 160000 nM
Compound 4: middle estimate off by 1.1-fold (0.03 log units), on the low side, within the range that was stated.
By their numbers in this assay, from the lowest: compounds 3, 2, 4 and 1 (each within the scatter of the next).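

In this assay, pyridin-3-yl in place of 4-(dimethylamino)phenyl gives a 1.1-fold lower number from compound 1 to compound 4 (0.05 log units; within the scatter), so exchanging the six-membered aromatic ring itself, and not only the group it carries, also stays within the scatter. The entering group is smaller, with 6 heavy atoms against 9, and has a hetero atom in its ring, so the read-out at this aromatic nitrogen has now held through a change in both size and ring make-up. Nothing available explains why the number holds so steady.

On these data alone, all four compounds keep a six-membered aromatic ring on that nitrogen, so it remains open whether a cyclohexyl ring or a butyl chain there would leave the number in place. Changes elsewhere on the shared core also remain open, such as a carboxylic acid in place of the ethyl ester.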